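Second chloro on the pendant ring: expectation notes

The source may hold more compounds than are shown below. What is called first, only, known or untested is meant among the compounds shown, and "the series" means these compounds.

Among the measured compounds shown here, compound 1 `Cc1nn(C)c2c1C(c1cccc(Cl)c1)=NCCN2` is the only member of this set with a number in a functional assay on the whole organism for positive allosteric modulation, with Rattus norvegicus as the target; a higher number here means that more compound is needed for the effect, a lower number that less compound is needed: compound 1 gives 0.63 mg/kg. Compound 2 `Cc1nn(C)c2c1C(c1ccccc1)=NCCN2CCCN(C)C` reaches only a limit of the assay, > 10 mg/kg. Compound 3 `Cc1nn(C)c2c1C(c1ccccc1Cl)=NCCN2CCCN(C)C` likewise sits at a limit, > 10 mg/kg. The difference between the cores of compound 1 and compound 2 is not broken down here. From compound 2 to compound 3 the change is chloro in place of hydrogen on an aromatic carbon; its step, a step that the two limits leave unreadable from compound 2 to compound 3, cannot be read, since the limit of > 10 mg/kg in this assay, at which 2 of the 3 values shown sit, is where both values sit.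

Compound 4 `Cc1nn(C)c2c1C(c1ccc(Cl)c(Cl)c1)=NCCN2` is not yet measured. From compound 1 to compound 4 the change is chloro in place of hydrogen on an aromatic carbon, the same kind of change as from compound 2 to compound 3 but at a different place: here the entering chloro is ortho to a chloro group and para to a large group, whereas in compound 3 it is ortho to a large group. For the measured compounds named here, the one measured instance of this kind of change gives no readable size, so nothing carries over. For compound 4 a step of a 1.6-fold higher number from compound 1 to compound 4 (0.20 log units; within the scatter) is expected, resting only on compound 1 at 0.63 mg/kg. The estimate for compound 4 in this assay is 1 mg/kg, with a range from 0.3 mg/kg to 5 mg/kg.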

Compound 4, minimum effective dose: 2.5 mg/kg
Beside the measured number, compound 4's estimate is 2.5-fold (0.40 log units) below it, and the stated range covers the measured number.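

In this assay, adding the chloro to the core of compound 1 gives a 4.0-fold higher number from compound 1 to compound 4 (0.60 log units; beyond the scatter), so on this core more compound is needed once the second chloro is present. This is a single readable instance, at one place on the ring: the entering chloro is ortho to a chloro group and para to a large group. The same kind of change from compound 2 to compound 3 sits at a different place on another core and cannot be read, because both of its values are limits and not numbers, so nothing shows whether the step carries from one core to the other: the limit of > 10 mg/kg in this assay, at which 2 of the 4 values shown sit.

Still open, from the compounds shown here alone, is whether the higher number belongs to chloro itself or would also follow from a fluoro, a methoxy or a nitrile at the same place on the ring of compound 1. Also open, going by these compounds, is whether any group on the ring of compound 2 would bring that core to a readable number in this assay.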